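A few compounds are considered here, and "the series" means these few. Any claim that something is new, unique, unknown or untested is made for them only; others in the source may bear on it.

Measured compounds in an assay on SH-EP1 cells for agonist activity at Neuronal acetylcholine receptor; alpha4/beta2 (Homo sapiens), read by FLIPR and calcium flux; a higher number here means that more compound is needed for the effect, a lower number that less compound is needed:
compound 1 `CCCC(=O)N1CC2CC(C1)N2` gives 850 nM
compound 2 `O=C(C1CCCC1)N1CC2CC(C1)N2` gives 29000 nM
compound 3 `O=C(C1CC=CC1)N1CC2CC(C1)N2` gives 17000 nM

Compound 1 holds the lowest of the three numbers. The nearest to it is compound 3, and the gap from compound 1 to compound 3 is beyond the scatter; the furthest is compound 2, also beyond the scatter. Among the compounds with values here, no pair of measured compounds differs in a single place, so no step can be read off directly. What the values show is that the two compounds carrying a five-membered ring on the carbonyl carbon both sit well above compound 1 with its propyl chain.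

Compound 4 `O=C([C@@H]1C[C@@H]1F)N1CC2CC(C1)N2` is the next compound for this assay. Against compound 1 the change is 2-fluorocyclopropyl in place of propyl on a carbonyl carbon. Within the data shown here, the only guidance is that a ring in this position, in compound 2 and compound 3, goes with much higher numbers than compound 1; the three-membered ring of compound 4 is a smaller change than either of those, and no measured compound tells how a ring of this size or the fluorine behaves here. A step upward from compound 1 to compound 4 is expected, beyond the scatter but short of the gaps to compound 2 and compound 3; the expected step is a 4.1-fold higher number from compound 1 to compound 4 (0.61 log units; beyond the scatter). For compound 4 the estimate is 3500 nM, with a range from 800 nM to 15000 nM.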

Compound 4, half-maximal effective concentration: 370 nM
Estimate against measurement, compound 4: 9.5-fold (0.98 log units) above; the whole stated range lies above it.
By their numbers in this assay, from the lowest: compound 4; then compound 1; then compounds 3 and 2 (each within the scatter of the next).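

In this assay, 2-fluorocyclopropyl in place of propyl on a carbonyl carbon gives a 2.3-fold lower number from compound 1 to compound 4 (0.36 log units; beyond the scatter), so this position can carry a ring and still give a lower number than the open chain. The earlier link between a ring here and a much higher number therefore holds only for the five-membered rings of compound 2 and compound 3, and compound 4 goes against it. No measurement shown explains the step, and no reason can be given for the contrast among the ring-bearing compounds.

Going by these compounds, it remains open whether the three-membered ring, the fluorine or the arrangement at the two defined stereocentres accounts for the lower number, as the change in compound 4 introduces all three at once; plain cyclopropyl and the other stereoisomers of 2-fluorocyclopropyl would separate these contributions. Also open, on these data alone, is how the numbers run with ring size and chain length on the carbonyl carbon, which cyclobutyl and a longer chain such as pentyl would begin to show.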